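Adenosine benzylamines in G-361 antiproliferation: two inactive analogues

A few compounds are considered here, and "the series" means these few. Any claim that something is new, unique, unknown or untested is made for them only; others in the source may bear on it.

Measured so far:
compound 1 `OC[C@H]1O[C@@H](n2cnc3c(NCc4ccc(F)cc4)ncnc32)[C@H](O)[C@@H]1O`: > 166000 nM
compound 2 `OC[C@H]1O[C@@H](n2cnc3c(NCc4ccc(Cl)cc4)ncnc32)[C@H](O)[C@@H]1O`: > 166000 nM

In a functional assay on G-361 cells (Homo sapiens) for antiproliferative activity, with a stated time of 72 h (on this read-out higher numbers stand for weaker inhibition and lower numbers for stronger inhibition), compound 1 gives > 166000 nM, which is a limit of the assay. In this assay compound 2 likewise gives > 166000 nM, again a limit. For the measured compounds named here, the one measured step is a step that the two limits leave unreadable from compound 1 to compound 2. Compound 3 `Cc1ccc(O)c(CNc2ncnc3c2ncn3[C@@H]2O[C@H](CO)[C@@H](O)[C@H]2O)c1` differs from compound 2 by 2-hydroxy-5-methylphenyl in place of 4-chlorophenyl on a saturated chain carbon bound to a nitrogen on an aromatic ring. Going by the values given here, no measured step bears on this change, and compound 2 stands at the limit of > 166000 nM in this assay, at which 2 of the 2 values shown sit. Compound 3 is therefore expected to remain at or near the same limit, with a step that the limit leaves unreadable from compound 2 to compound 3 estimated. The estimate for compound 3 is 200000 nM, ranging from 50000 nM to 800000 nM.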

Compound 3, half-maximal inhibitory concentration: > 166000 nM
Compound 3 ended at the assay's limit; the forecaster's own chance of this, stated with the estimate: 80%; the middle value lies beyond the limit too.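

No step among compound 1, compound 2 and compound 3 can be read, as all three stop at a limit: the limit of > 166000 nM in this assay, at which 3 of the 3 values shown sit.

From the compounds shown here alone, whether any other group in this place on the shared core gives a readable value in this assay stays open.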